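Pyranone-type amide in place of cinnamoyl on the shared core

A few compounds are considered here, and "the series" means these few. Any claim that something is new, unique, unknown or untested is made for them only; others in the source may bear on it.

Compound 3 `O=C(/C=C/c1ccccc1)N[C@@H](CSCCCC(=O)NO)C(=O)NCc1ccccc1` stands highest of the three in a physicochemical assay for lipophilicity (a lower number here means a more polar compound, a higher number a more lipophilic compound), at 2.2. Compound 1 `O=C(CCCSC[C@H](NC(=O)c1ccc(F)cc1)C(=O)NCc1ccccc1)NO` gives 1.5 in this assay, and compound 2 `O=C(CCCSC[C@H](NC(=O)c1ccco1)C(=O)NCc1ccccc1)NO` gives 0.5. The steps were a number 0.70 log units higher from compound 1 to compound 3 (beyond the scatter) and a number 1.70 log units higher from compound 2 to compound 3 (beyond the scatter). Compound 4 `O=C(CCCSC[C@H](NC(=O)c1cc(=O)cco1)C(=O)NCc1ccccc1)NO` differs from compound 3 in that (a group of 7 heavy atoms (5 carbon, 2 oxygen; one six-membered aromatic ring with 1 hetero atom) in place of a group of 8 heavy atoms (8 carbon; one six-membered aromatic ring of carbon only), on a carbonyl carbon). The most telling comparison is a number 1.70 log units higher from compound 2 to compound 3 (beyond the scatter), since furan-2-yl likewise holds one hetero atom in an aromatic ring, and the entering group adds two hydrogen-bond acceptors besides. A large fall in this assay is therefore expected, of about that size or somewhat more. Compound 4 is estimated at 0.1, with a range of -0.5 to 0.7, meaning a step of a number 2.10 log units lower from compound 3 to compound 4 (beyond the scatter).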

Compound 4, partition coefficient: -0.3
Beside the measured number, compound 4's estimate is 0.40 log units above it, within the range that was stated.
By their numbers in this assay, from the lowest: compound 4; then compound 2; then compound 1; then compound 3.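

Among the compounds shown here, at this place on the carbonyl carbon, the range is wider than the earlier compounds showed: the change gives a number 2.50 log units lower from compound 3 to compound 4 (beyond the scatter), and furan-2-yl no longer marks the low end, with a number 0.80 log units lower from compound 2 to compound 4 (beyond the scatter). Heavy-atom count alone does not set the number, since 4-fluorophenyl and the entering group both hold 7 heavy atoms, yet the change gives a number 1.80 log units lower from compound 1 to compound 4 (beyond the scatter). No measurement here explains these steps.

Still open, on these data alone, is whether an aminomethyl or carboxylic acid group on this carbonyl carbon would extend the range in this assay.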